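The compounds below may be only part of what the source reports. "The series", "measured", "known", "first", "only" and "open" are said of these compounds alone.

Measured so far in a functional assay on HeLa cells (Homo sapiens) for cytotoxicity, read by MTT assay, with a stated time of 48 h; a lower number here means a stronger inhibitor, a higher number a weaker inhibitor:
- compound 1 `CCOC(=O)c1c(-c2c(Cl)c3ccccc3oc2=O)nn(-c2cccc(C)c2)c1C(=O)OCC`: 30000 nM
- compound 2 `CCOC(=O)c1c(-c2c(Cl)c3cc(C)ccc3oc2=O)nn(-c2cccc(Cl)c2)c1C(=O)OCC`: 125000 nM
- compound 3 `CCOC(=O)c1c(-c2cc3ccccc3oc2=O)nn(-c2cccc(C)c2)c1C(=O)OCC`: 245000 nM

Compound 3 gives the highest number of the three in this assay; compound 2 stands within the scatter of it, while compound 1 stands clearly lower. The only single-point step among these is an 8.2-fold higher number from compound 1 to compound 3 (0.91 log units; beyond the scatter), hydrogen in place of chloro on an aromatic carbon. Compounds 1 and 2 differ in two places at once, so their values are simply noted side by side.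

Compound 4 `CCOC(=O)c1c(-c2cc3ccccc3oc2=O)nn(-c2ccc(OC)cc2)c1C(=O)OCC` is the next member: 4-methoxyphenyl in place of 3-methylphenyl on an aromatic nitrogen. Within the data shown here, no measured pair isolates a change of the group on the aromatic nitrogen, so the step from compound 1 to compound 3 does not bear on it directly, and there is no step of the same kind to lean on. On this basis no movement beyond the scatter is expected from compound 3 to compound 4, that is a 1.0-fold higher number from compound 3 to compound 4 (0.01 log units; within the scatter). The estimate for compound 4 in this assay is therefore 250000 nM, expected to lie between 80000 nM and 800000 nM.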

Compound 4, half-maximal inhibitory concentration: 90000 nM
Beside the measured number, compound 4's estimate is 2.8-fold (0.44 log units) above it; measured number inside the range.
By their numbers in this assay, from the lowest: compound 1; then compounds 4, 2 and 3 (each within the scatter of the next, the first and the last beyond it).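

In this assay, among these compounds, the group on the aromatic nitrogen can move the number with the rest of the structure unchanged, as a 2.7-fold lower number from compound 3 to compound 4 (0.43 log units; beyond the scatter) shows, whereas the only earlier single-place step concerned an aromatic carbon. The exchange alters two things together, methyl against methoxy and the place of that group on the phenyl ring, so the shift belongs to the change from 3-methylphenyl to 4-methoxyphenyl as a whole and not to either part. Nothing shown gives a reason for the shift.

A 4-methylphenyl or 3-methoxyphenyl group on the same nitrogen would separate the two parts, and an unsubstituted phenyl would give a reference point. Going by these compounds, whether the shift holds with chloro on the aromatic carbon, as in compound 1, stays open.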